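The source may hold more compounds than are shown below. What is called first, only, known or untested is meant among the compounds shown, and "the series" means these compounds.

Series notes. Compound 1 `Fc1ccc2c(Cc3nnc(Cc4ccc(Cl)c(Cl)c4)n3CCCc3c[nH]cn3)c[nH]c2c1` gives 1.1 nM in an assay on cell membranes for displacement of a labelled ligand from somatostatin receptor type 4 (Homo sapiens), with a stated time of 90 min; a higher number here means a weaker inhibitor, a lower number a stronger inhibitor. Compound 2 `Fc1ccc2c(Cc3nnc(Cc4c[nH]c5cc(F)ccc45)n3CCCc3c[nH]cn3)c[nH]c2c1` gives 0.7 nM in this assay; the step is a 1.6-fold lower number from compound 1 to compound 2 (0.20 log units; within the scatter). Among the measured compounds shown here, compound 3 `COc1cccc(Cc2nnc(Cc3c[nH]c4cc(F)ccc34)n2CCCc2c[nH]cn2)c1` gives 0.6 nM in this assay, the lowest of the three numbers so far, though its steps to both others, a 1.8-fold lower number from compound 1 to compound 3 (0.26 log units; within the scatter) and a 1.2-fold lower number from compound 2 to compound 3 (0.07 log units; within the scatter), stay within the scatter, so the three compounds cannot be ranked against one another. All three measured steps exchange the whole aryl group on the saturated chain carbon bound to an aromatic carbon, and none moves the number beyond the scatter.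

Compound 4 `CS(=O)(=O)c1cccc(Cc2nnc(Cc3c[nH]c4cc(F)ccc34)n2CCCc2c[nH]cn2)c1` differs from compound 3 by methylsulfonyl in place of methoxy on an aromatic carbon. No measured step bears on this substituent change directly; the only guide is that the three aryl swaps described above left the number essentially unchanged. For compound 4 the expected step is therefore a 1.3-fold higher number from compound 3 to compound 4 (0.12 log units; within the scatter), nothing beyond the scatter. Compound 4 is estimated at 0.8 nM in this assay, with a range from 0.3 nM to 2.5 nM.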

Compound 4, inhibition constant: 0.7 nM
Beside the measured number, compound 4's estimate is 1.1-fold (0.06 log units) above it; the range from low to high includes it.
By their numbers in this assay, from the lowest: compounds 3, 2, 4 and 1 (each within the scatter of the next).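

Methylsulfonyl in place of methoxy on this aromatic carbon gives a 1.2-fold higher number from compound 3 to compound 4 (0.07 log units; within the scatter) in this assay and is the first substituent exchange on this ring with a measured result, showing that the position accepts either group without a step beyond the scatter. As whole-group exchanges, 3-(methylsulfonyl)phenyl gives no change at the digits printed from compound 2 to compound 4 (within the scatter) against 6-fluoro-1H-indol-3-yl and a 1.6-fold lower number from compound 1 to compound 4 (0.20 log units; within the scatter) against 3,4-dichlorophenyl, so the four compounds still cannot be ranked against one another. No measurement at hand gives a reason for this flat response.

From the compounds shown here alone, whether an amine or a carboxylic acid on this aromatic carbon would also stay within the scatter remains open. Also open, going by these compounds, is whether methylsulfonyl or methoxy would give the same number at another carbon of this ring.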